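Benzyl for 3,4-difluorophenyl on the amine nitrogen

The source may hold more compounds than are shown below. What is called first, only, known or untested is meant among the compounds shown, and "the series" means these compounds.

The series shares one core, seen in compound 1 `Cc1ccc(S(=O)(=O)/N=C(/CCNC2=CC(=O)c3ccccc3C2=O)Nc2ccccc2[N+](=O)[O-])cc1` and compound 2 `Cc1ccc(S(=O)(=O)/N=C(/CCNC2=CC(=O)c3ccccc3C2=O)Nc2ccc(F)c(F)c2)cc1`. In a functional assay on A549 cells (Homo sapiens) for cytotoxicity, read by MTT assay, with a stated time of 48 h (a lower number here means a stronger inhibitor, a higher number a weaker inhibitor), compound 1 gives 5010 nM; compound 2 gives 16700 nM, the higher of the two numbers, and the step of a 3.3-fold higher number from compound 1 to compound 2 (0.52 log units; beyond the scatter) carries the whole spread so far. Compound 3 `Cc1ccc(S(=O)(=O)/N=C(/CCNC2=CC(=O)c3ccccc3C2=O)NCc2ccccc2)cc1` is the next member, differing from compound 2 by benzyl in place of 3,4-difluorophenyl on an amine nitrogen. Among the compounds with values here, no measured step bears directly on this change: the one step in hand swaps one aromatic ring for another on the same nitrogen, whereas here a benzyl enters, so the only guide is that a change at this nitrogen moved the number modestly. Compound 3 is therefore expected to sit near compound 2, with the step of a 1.4-fold lower number from compound 2 to compound 3 (0.14 log units; within the scatter) estimated as small and of uncertain direction. The estimate for compound 3 is 12000 nM, within 4000 nM to 40000 nM.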

Compound 3, half-maximal inhibitory concentration: 7410 nM
Compound 3: middle estimate off by 1.6-fold (0.21 log units), on the high side, and the stated range covers the measured number.
By their numbers in this assay, from the lowest: compounds 1 and 3 (each within the scatter of the next); then compound 2.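

In this assay, benzyl on the amine nitrogen gives a 2.3-fold lower number from compound 2 to compound 3 (0.35 log units; beyond the scatter), so a ring attached directly to this nitrogen is not needed to reach the lower numbers seen so far in the series. Benzyl and 2-nitrophenyl cannot be separated at this position, with a 1.5-fold higher number from compound 1 to compound 3 (0.17 log units; within the scatter), which leaves compound 2 alone at the high end among the three groups compared. Nothing available explains why 3,4-difluorophenyl stands apart from the other two groups.

As far as these compounds go, it remains open whether that gap follows the two fluorines or the directly attached ring, a question that unsubstituted phenyl on the same nitrogen would address. The response to a longer chain, such as 2-phenylethyl, or to a non-aromatic group, such as cyclohexyl, is also unknown.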